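Replacing the hydroxycarbamoyl group in an indole-free analog

The compounds below may be only part of what the source reports. "The series", "measured", "known", "first", "only" and "open" are said of these compounds alone.

Three measured compounds share a hydroxycarbamoyl terminus on a saturated chain. Compound 1 `Nc1ncnc2c1c(-c1cnc3[nH]ccc3c1)nn2CCCCCCCCCC(=O)NO` gives 98.3% in an assay on isolated protein for inhibition of protein deacetylase HDAC6 (Homo sapiens), with a stated time of 15 min, tested at 1 uM (on this read-out higher numbers stand for more inhibition at the one concentration tested (going by the name of the read-out) and lower numbers for less inhibition), compound 2 `Nc1ncnc2c1c(-c1cnc3[nH]ccc3c1)nn2CCCCCCC(=O)NO` gives 99.1%, and compound 3 `Nc1nc2cc(-c3nn(CCCCC(=O)NO)c4ncnc(N)c34)ccc2o1` gives 95.1%. Compound 3 has the lowest of the three numbers, but its gaps to compound 1 and compound 2 are both within the scatter. For the measured compounds named here, the only measured step, a number 0.8 percentage points higher from compound 1 to compound 2 (within the scatter), shortens the chain and leaves the end group untouched.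

Compound 4 `CNC(=O)CCCCCCCn1nc(-c2ccc3oc(N)nc3c2)c2c(N)ncnc21` differs from compound 3 by 3-(methylcarbamoyl)propyl in place of hydroxycarbamoyl on a saturated chain carbon, four bonds along the chain from an aromatic nitrogen. Going by the values given here, no measured step bears on this change: every measured compound keeps the hydroxycarbamoyl group, and the one step that was measured concerns chain length only. Because compound 3 gives 95.1% with that group, near the top of the scale like the other measured compounds, the expectation for compound 4 is that losing it brings a step of a number 75.1 percentage points lower from compound 3 to compound 4 (beyond the scatter), downward and well beyond the scatter. Compound 4 is therefore estimated at 20%, within a range from 0% to 60%.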

Compound 4, a percentage reported as inhibition, at one concentration (the size of the read-out at that concentration, not a potency): 99.1%
Compound 4: middle estimate off by 79.1 percentage points, on the low side; measured number outside the range, above it.
By their numbers in this assay, from the lowest: compounds 3, 1, 2 and 4 (each within the scatter of the next).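

In this assay, putting 3-(methylcarbamoyl)propyl in place of hydroxycarbamoyl, on a saturated chain carbon, four bonds along the chain from an aromatic nitrogen, gives a number 4 percentage points higher from compound 3 to compound 4 (within the scatter). For the compounds shown here, every earlier compound carried hydroxycarbamoyl, so only this pair shows that, at the one concentration tested, a high percentage does not depend on that group. No available evidence accounts for this result.

This single change alters the end group and lengthens the chain together, so the compounds shown do not separate the two, and a percentage at one concentration does not tell whether compound 3 and compound 4 differ in potency. As far as these compounds go, it also remains open whether a carboxylic acid or a primary amide at the end of the chain would read as high.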